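Trimming the Enone Aryl Group of Compound 2

The compounds below may be only part of what the source reports. "The series", "measured", "known", "first", "only" and "open" are said of these compounds alone.

Of the compounds shown here, three sharing one core have been measured in a functional assay on ACHN cells (Homo sapiens) for inhibition; on this read-out higher numbers stand for weaker inhibition of growth and lower numbers for stronger inhibition of growth. Compound 1 `COc1cc(/C=C/C(=O)c2cccc(-n3cc(-c4ccc(Cl)cc4)[nH]c3=O)c2)ccc1O` gives 2190 nM, compound 2 `COc1cc(/C=C/C(=O)c2cccc(-n3cc(-c4ccccc4)[nH]c3=O)c2)ccc1O` gives 2500 nM, and compound 3 `COc1ccc(-c2cn(-c3cccc(C(=O)/C=C/c4ccc(O)c(OC)c4)c3)c(=O)[nH]2)cc1` gives 3400 nM. Compound 2 stands second highest of the three: its nearest neighbour is compound 1, as the step of a 1.1-fold higher number from compound 1 to compound 2 (0.06 log units; within the scatter) shows, and its furthest is compound 3, as a 1.4-fold higher number from compound 2 to compound 3 (0.13 log units; within the scatter) shows. Both steps lie within the scatter, as does a 1.6-fold higher number from compound 1 to compound 3 (0.19 log units; within the scatter).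

Compound 4 `O=C(/C=C/c1cccc(O)c1)c1cccc(-n2cc(-c3ccccc3)[nH]c2=O)c1` has not yet been measured. It differs from compound 2 in one place: 3-hydroxyphenyl in place of 4-hydroxy-3-methoxyphenyl on a double-bonded chain carbon bound to a double-bonded chain carbon.

Going by the values given here, none of the measured steps touches this part of the molecule; all three concern the other aromatic ring, where chloro, hydrogen and methoxy were exchanged without any step beyond the scatter. Among the compounds with values here, the only guidance the data give is that small exchanges on an aromatic ring have left this assay nearly unchanged, and on that basis no step beyond the scatter is expected from compound 2 to compound 4 either, the estimated step being a 1.4-fold higher number from compound 2 to compound 4 (0.15 log units; within the scatter). Within the data shown here, no measured pair speaks to the changed position, and the range is set wide. Compound 4 is expected to give 3500 nM, between 1200 nM and 10000 nM.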

Compound 4, concentration for 50% growth inhibition: 2760 nM
Compound 4: the middle estimate sits 1.3-fold (0.10 log units) above what was measured, and the stated range covers the measured number.
By their numbers in this assay, from the lowest: compounds 1, 2, 4 and 3 (each within the scatter of the next).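

The aryl group on the double-bonded chain carbon had not been touched by any earlier step, and compound 4 now provides the first reading there: in this assay, the exchange of 4-hydroxy-3-methoxyphenyl for 3-hydroxyphenyl gives a 1.1-fold higher number from compound 2 to compound 4 (0.04 log units; within the scatter). The group shrinks from 9 heavy atoms to 7 and from 2 hydrogen-bond acceptors to 1, and this single pair shows that, on this read-out, such an exchange can be made without a step beyond the scatter, as was also true of the exchanges on the other aromatic ring. No measurement is available that would explain this result.

Because this one exchange alters the methoxy group and the hydroxy group together, the pair cannot separate what each contributes, and it leaves open whether a hydroxy group is needed on this ring at all. It also leaves open how this read-out would respond to a larger exchange at this place, such as an amine or a carboxylic acid on the ring, or a longer chain in place of the ring.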